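Methyl on the ring nitrogen: from compound 2 to compound 3

The source may report more compounds than this note shows. Statements on the series, on what has been measured and on what is new or still open speak of the compounds shown alone.

Measured compounds:
compound 1 `CN1C[C@H]2C=C(c3cccnc3)C[C@H](C2)C1` gives 31%
compound 2 `C1=C(c2cccnc2)C[C@@H]2CNC[C@H]1C2` gives 139%

Of the compounds shown here, two have been measured in an in vitro functional assay on SH-SY5Y cells for agonist activity at Neuronal acetylcholine receptor; alpha3/beta4 (Homo sapiens), read by FLIPR and calcium flux; on this read-out higher numbers stand for larger maximal responses and lower numbers for smaller maximal responses. Compound 2 stands highest of the two numbers; its nearest neighbour is compound 1, whose value lies far lower, a gap beyond the usual scatter of this assay. Among the measured compounds shown here, no pair of measured compounds differs in a single place, so no step has been resolved between them; the two values simply show that compound 2 reaches a much larger response than compound 1.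

The next compound, compound 3 `CN1C[C@@H]2C=C(c3cccnc3)C[C@@H](C2)C1`, has not yet been measured in this assay. Compared with compound 2, it carries methyl in place of hydrogen on an amine nitrogen in a ring. What this change does is not known from measured pairs. The lower number in the set belongs to compound 1, and compound 3 shares with it a methyl on a ring nitrogen, so a fall is expected rather than a rise, with wide uncertainty. The step from compound 2 to compound 3 is estimated as a number 79 percentage points lower from compound 2 to compound 3 (beyond the scatter), beyond the scatter and downward. For compound 3 the expected value in this assay is 60%, with a range from 25% to 115%.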

Compound 3, largest response reached (reported as percent of maximum), in percent of the reference or control that the assay uses: 25%
Compound 3: the middle estimate sits 35 percentage points above what was measured; the measured number falls inside the stated range.
By their numbers in this assay, from the lowest: compounds 3 and 1 (each within the scatter of the next); then compound 2.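

Among the compounds shown here, at this position, on an amine nitrogen in a ring, the single change of methyl in place of hydrogen can now be read on its own in this assay: it gives a number 114 percentage points lower from compound 2 to compound 3 (beyond the scatter), a large step. Before this result, no measured pair differed in one place, and the methyl had no step of its own. Inverting all the stereocentres of the methyl-bearing compounds leaves no readable difference in this assay, with a number 6 percentage points lower from compound 1 to compound 3 (within the scatter), and the comparison is a clean one for configuration alone: the fact that compounds 1 and 3 differ only in the configuration as drawn

The compounds shown leave open how an ethyl group or a longer chain on this ring nitrogen would read in this assay, and so whether the response depends on the size of the group that replaces hydrogen or is already lost with methyl. They also leave open whether the amine bearing hydrogen is as indifferent to configuration as the methyl-bearing pair, since the mirror image of compound 2 does not stand among them.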